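Compound 3: swapping methoxymethyl for carboxy

The compounds below may be only part of what the source reports. "The series", "measured", "known", "first", "only" and "open" are said of these compounds alone.

- compound 1 `C[C@H](O)Cc1cc(-c2ccnc3[nH]nc(C(F)(F)F)c23)cc(C2(C#N)CC2)c1` gives 37%
- compound 2 `COCCc1cc(-c2ccnc3[nH]nc(C(F)(F)F)c23)cc(C2(C#N)CC2)c1` gives 90%

Both values come from an ADME assay on S9 fraction from liver (Rattus norvegicus) for metabolic stability, read by LC-MS, using NADPH, with a stated time of 60 min, tested at 10 uM; a higher number here means that more of the compound is left, a lower number that less of the compound is left. Compound 2 holds the higher of the two numbers, and the gap to compound 1 is large, as the step of a number 53 percentage points higher from compound 1 to compound 2 (beyond the scatter) shows.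

The next compound, compound 3 `N#CC1(c2cc(CC(=O)O)cc(-c3ccnc4[nH]nc(C(F)(F)F)c34)c2)CC1`, keeps the shared core and differs from compound 2 in one place: carboxy in place of methoxymethyl on a saturated chain carbon bound to an aromatic carbon. In words, carboxy stands in place of methoxymethyl on a saturated chain carbon bound to an aromatic carbon.

Going by the values given here, only one measured step bears on this change. The step of a number 53 percentage points higher from compound 1 to compound 2 (beyond the scatter) lies at the same place and shows that a swap there can move the number a long way. However, it involves different groups, and no compound with carboxy has been measured yet. Compound 2, at 90%, also leaves little room for a rise. The expectation is therefore a small drop that stays within the scatter, though a larger one is possible. The expected step is a number 8 percentage points lower from compound 2 to compound 3 (within the scatter). For compound 3 the estimated value is 82%, with an expected range from 60% to 98%.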

Compound 3, percent of the compound remaining: 95%
For compound 3 the middle estimate is 13 percentage points below the measured one; the measured number falls inside the stated range.
By their numbers in this assay, from the lowest: compound 1; then compounds 2 and 3 (each within the scatter of the next).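

In this assay carboxy in place of methoxymethyl gives a number 5 percentage points higher from compound 2 to compound 3 (within the scatter) so the two groups cannot be told apart here, even though carboxy carries 1 hydrogen-bond donor and 1 double bond outside aromatic rings that methoxymethyl lacks. Carboxy in place of 1-hydroxyethyl gives a number 58 percentage points higher from compound 1 to compound 3 (beyond the scatter) and this shows that the high number seen with compound 2 is not tied to methoxymethyl alone: a second, quite different group on the saturated chain carbon bound to an aromatic carbon sits equally far from compound 1. Nothing shown here gives a reason for the low number of compound 1 or for the high numbers of the other two compounds.

From the compounds shown here alone, it remains open whether an amine, a primary amide or a longer chain at this place would stay level with compound 2 and compound 3 or drop towards compound 1. Also open, going by these compounds, is whether the 1-hydroxyethyl group itself accounts for the low number, a question that the methyl ether or the opposite mirror-image form of that alcohol could help to settle.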